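Carboxy in Place of Methyl on the Aromatic Ring

The compounds below may be only part of what the source reports. "The series", "measured", "known", "first", "only" and "open" are said of these compounds alone.

Compound 1, `CCN(Cc1cccs1)C(=O)COc1ccc(C)cc1`: 8 nM
Compound 2, `Cc1ccc(OCC(=O)N(Cc2cccs2)C(C)(C)C)cc1`: 11000 nM
Compound 3, `CCN(Cc1nccs1)C(=O)COc1ccc(C)cc1`: 3060 nM

Of the compounds shown here, three with a shared core have been measured in an assay on HEK293 cells for agonist activity at transient receptor potential cation channel subfamily M member 8 (Homo sapiens), read by fluorescence and calcium flux, with a stated time of 15 min; a lower number here means that less compound is needed, a higher number that more compound is needed for the effect. Compound 1 gives the lowest number of the three in this assay; the other two stand far above it. Putting tert-butyl in place of ethyl on the amide-type nitrogen, as in compound 2, gives a 1400-fold higher number from compound 1 to compound 2 (3.14 log units; beyond the scatter). Putting 1,3-thiazol-2-yl in place of thiophen-2-yl on the saturated chain carbon bound to that nitrogen, as in compound 3, gives a 380-fold higher number from compound 1 to compound 3 (2.58 log units; beyond the scatter). Both measured changes sit on the nitrogen side of the core, and both were costly.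

Compound 4, `CCN(Cc1cccs1)C(=O)COc1ccc(C(=O)O)cc1`, differs from compound 1 at the other end of the molecule: carboxy in place of methyl on an aromatic carbon. Among the measured compounds shown here, neither measured step touches this six-membered aromatic ring of carbon only, so no step bears directly on the new change. What the two steps show is that each alteration of compound 1 tried so far raised the number by a large amount. A carboxy group entering where a methyl stood is a larger change than either of those, so a higher number, beyond the scatter, is expected, with wide uncertainty.

Compound 4 is therefore estimated to give 2000 nM in this assay, within a range from 150 nM to 25000 nM. This corresponds to an expected step of a 250-fold higher number from compound 1 to compound 4 (2.40 log units; beyond the scatter).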

Compound 4, half-maximal effective concentration: "not active" (no number reported)
Nothing numeric was reported for compound 4; the estimate stays without a comparison.
By their numbers in this assay, from the lowest: compound 1; then compound 3; then compound 2.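

Among the compounds shown here, compound 4 is reported in this assay as "not active", with no number, so no step from compound 1 to compound 4 can be read. The compounds shown leave open how other groups in place of methyl on this aromatic carbon would compare with compound 1. No evidence shown bears on the result for compound 4.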